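The source may report more compounds than this note shows. Statements on the series, on what has been measured and on what is new or still open speak of the compounds shown alone.

Compound 3, `COc1cccc(-c2c(S(=O)(=O)c3cc(F)cc(F)c3)cnc3cc(F)ccc23)c1`, carries a 3-methoxyphenyl group on the shared core and a 3,5-difluorophenyl on the sulfonyl sulfur. In an ADME assay on microsomes from liver (Homo sapiens) for metabolic stability, tested at 2.5 uM (a lower number here means slower removal, a higher number faster removal of the compound), compound 3 gives 1.81 mL/min, the second highest of the three numbers shown. Its nearest neighbour is compound 1, `COc1cccc(-c2c(S(=O)(=O)c3ccc(OC)c(Cl)c3)cnc3cc(F)ccc23)c1`, which in this assay gives 1.71 mL/min; the step of a 1.1-fold higher number from compound 1 to compound 3 (0.02 log units; within the scatter) is within the scatter. The remaining measured compound is compound 2, `COc1cccc(S(=O)(=O)c2cnc3cc(F)ccc3c2-c2cccc(Cl)c2)c1`, which in this assay gives 2.97 mL/min.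

Compound 4, `O=S(=O)(c1cc(F)cc(F)c1)c1cnc2cc(F)ccc2c1-c1cccc(Cl)c1`, differs from compound 3 in one place: chloro in place of methoxy on an aromatic carbon. Among the measured compounds shown here, no measured step in the set makes exactly this change on its own. For the measured compounds named here, the only step on record, from compound 1 to compound 3, concerns the sulfonyl aryl group and is within the scatter, so it says nothing about this position. Compound 2 does carry a 3-chlorophenyl group on the core, but it also differs from compound 3 in the sulfonyl aryl, so only its value can be noted, not a step.

With so little to go on, compound 4 is expected to stay close to compound 3, with the step of a 1.3-fold higher number from compound 3 to compound 4 (0.12 log units; within the scatter) estimated to lie within the scatter. The estimate for compound 4 in this assay is 2.4 mL/min, with a range from 1.3 mL/min to 4.3 mL/min.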

Compound 4, intrinsic clearance in a liver preparation (reported as CLH), per the amount of preparation that the assay uses: 0.22 mL/min
Compound 4: the middle estimate sits 11-fold (1.04 log units) above what was measured; the whole stated range lies above it.
By their numbers in this assay, from the lowest: compound 4; then compounds 1, 3 and 2 (each within the scatter of the next).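

In this assay, the aromatic carbon carrying methoxy in compound 3 proves sensitive: chloro in place of methoxy gives an 8.2-fold lower number from compound 3 to compound 4 (0.92 log units; beyond the scatter), so the 3-chlorophenyl group on the core goes with much slower removal than the 3-methoxyphenyl group in this pair. The sulfonyl aryl group also matters: where a 1.1-fold higher number from compound 1 to compound 3 (0.02 log units; within the scatter) showed no change beyond the scatter, 3,5-difluorophenyl in place of 3-methoxyphenyl gives a 14-fold lower number from compound 2 to compound 4 (1.13 log units; beyond the scatter), although these two steps swap different groups and cannot be set directly against each other. Nothing among the data explains either step.

As far as these compounds go, what a fluoro or a nitrile would give in place of chloro remains open. So does whether chloro in place of methoxy has the same effect alongside other sulfonyl aryl groups, such as 3-chloro-4-methoxyphenyl.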